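The source may report more compounds than this note shows. Statements on the series, on what has been measured and on what is new or still open speak of the compounds shown alone.

Measured compounds in a functional assay on the whole organism (stomach) with Rattus norvegicus as the target; a lower number here means that less compound is needed, a higher number that more compound is needed for the effect:
Compound 1, `N#CNC(=N)NCCCCCn1nc(-c2ccccc2)ccc1=O`: in this assay compound 1 gives only a limit, > 100 mg/kg.
Compound 2, `CC/N=C(/NC#N)NCCCCn1nc(-c2ccccc2)cc(C)c1=O`: in this assay compound 2 gives 100 mg/kg.
Compound 3, `O=c1ccc(-c2ccccc2)nn1CCCCNC(=S)Nc1cccc2ccccc12`: in this assay compound 3 gives only a limit, > 100 mg/kg.

Compound 1 stands at the limit of > 100 mg/kg in this assay, at which 2 of the 3 values shown sit; its reading is a limit and not a number, so only its position at the edge of the measured range is known. Compound 2 gives a number at that same level, so whether compound 1 and compound 2 differ cannot be told. Within the data shown here, no step between two measured compounds that differ in one place is available.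

Compound 4, `N#CNC(=N)NCCCCn1nc(-c2ccccc2)ccc1=O`, not yet measured, differs from compound 1 by a group of 6 heavy atoms (2 carbon, 4 nitrogen; no ring) in place of a group of 7 heavy atoms (3 carbon, 4 nitrogen; no ring), on a saturated chain carbon, four bonds along the chain from an aromatic nitrogen. Among the measured compounds shown here, no measured pair shows what such a change does, so the step that the limit leaves unreadable from compound 1 to compound 4 is estimated to lie within the scatter, with no clear direction. Compound 4 is therefore expected near the limit, estimated at 150 mg/kg, range 60 mg/kg to 400 mg/kg, with a fair chance that this assay again reports only a limit.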

Compound 4, dose for half-maximal effect: 77.2 mg/kg
The estimate for compound 4 lay 1.9-fold (0.29 log units) above the measured number; measured number inside the range.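

Compound 4 gives a number at this position, 77.2 mg/kg, so the change can now be read at least in part. In this assay, the group of 6 heavy atoms in place of the group of 7 heavy atoms, on a saturated chain carbon, gives an at least 1.2-fold lower number from compound 1 to compound 4 (0.11 log units; that floor lies within the scatter), so a real difference between the two compounds is not established. Compound 1 gives only a limit, > 100 mg/kg, and the step is therefore a floor with its true size unknown: the limit of > 100 mg/kg in this assay, at which 2 of the 4 values shown sit.

From the compounds shown here alone, how far the number really falls with this change remains open, since the floor alone cannot show whether the full step goes beyond the scatter. Also open, going by these compounds, is how this assay responds to other groups on this saturated chain carbon, such as an amine, a carboxylic acid or a longer chain.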